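Varying the sulfonyl aryl group: a step to compound 4

A few compounds are considered here, and "the series" means these few. Any claim that something is new, unique, unknown or untested is made for them only; others in the source may bear on it.

Measured in a functional assay on PC-3 cells (Homo sapiens) for inhibition; a lower number here means a stronger inhibitor, a higher number a weaker inhibitor:
Compound 1, `COc1cc2nc(N3CCN(S(=O)(=O)c4ccc(Cl)cc4)CC3)nc(N)c2cc1OC`, 23000 nM
Compound 2, `COc1cc2nc(N3CCN(S(=O)(=O)c4ccc([N+](=O)[O-])cc4)CC3)nc(N)c2cc1OC`, 36000 nM
Compound 3, `COc1cc2nc(N3CCN(S(=O)(=O)c4ccc(S(C)(=O)=O)cc4)CC3)nc(N)c2cc1OC`, 17000 nM

Compound 3 shows the lowest of the three numbers in this assay; its nearest neighbour is compound 1, and the step of a 1.4-fold lower number from compound 1 to compound 3 (0.13 log units; within the scatter) lies within the scatter, whereas the step of a 2.1-fold lower number from compound 2 to compound 3 (0.33 log units; beyond the scatter) is modest. Compound 4, `COc1cc2nc(N3CCN(S(=O)(=O)c4cc(F)c(Cl)c(C(=O)O)c4)CC3)nc(N)c2cc1OC`, carries 3-carboxy-4-chloro-5-fluorophenyl in place of 4-(methylsulfonyl)phenyl on a sulfonyl sulfur. Among the compounds with values here, none of the measured steps matches this change directly. The steps of a 1.6-fold higher number from compound 1 to compound 2 (0.19 log units; within the scatter) and a 1.4-fold lower number from compound 1 to compound 3 (0.13 log units; within the scatter) each swap one group for another on an aromatic carbon and stayed small, so such swaps have moved the number little. Within the data shown here, the present change replaces more of the ring and has no measured counterpart. For compound 4 the expected step is a 1.5-fold higher number from compound 3 to compound 4 (0.17 log units; within the scatter), with wide uncertainty. The estimate for compound 4 in this assay is 25000 nM, between 8000 nM and 80000 nM.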

Compound 4, half-maximal inhibitory concentration: 56000 nM
Estimate against measurement, compound 4: 2.2-fold (0.35 log units) below, within the range that was stated.
By their numbers in this assay, from the lowest: compounds 3, 1, 2 and 4 (each within the scatter of the next, the first and the last beyond it).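

In this assay, the larger change on the sulfonyl sulfur gives a 3.3-fold higher number from compound 3 to compound 4 (0.52 log units; beyond the scatter) and a 2.4-fold higher number from compound 1 to compound 4 (0.39 log units; beyond the scatter), both modest but beyond the scatter, whereas a 1.6-fold higher number from compound 2 to compound 4 (0.19 log units; within the scatter) stays within it. Replacing the aryl group with 3-carboxy-4-chloro-5-fluorophenyl therefore keeps compound 4 level with compound 2 and brings no gain over compound 3. Nothing available explains this shift. Going by these compounds, it remains open whether a carboxylic acid alone on the phenyl ring, without the chlorine and fluorine, would account for the step, and how an amine there would compare.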